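The compounds below may be only part of what the source reports. "The series", "measured", "known", "first", "only" and "open" are said of these compounds alone.

Measured so far in a functional assay on the whole organism (strain Swiss albino) for inhibition, with Mus musculus as the target, in the writhing test, with stated times of 60 min and 15 min, at a dose of 100 mg/kg by the oral route; on this read-out lower numbers stand for less inhibition and higher numbers for more inhibition at the one dose given (going by the name of the read-out):
compound 1 `COc1cc2c(cc1OC)C(CC(=O)O)CC2`: 44%
compound 2 `CCCCCCNC(=O)CC1CCc2cc(OC)c(OC)cc21`: 82.2%

Compound 2 holds the higher of the two numbers in this assay, and compound 1 the lower. Going by the values given here, the single step, a number 38.2 percentage points higher from compound 1 to compound 2 (beyond the scatter), came with hexylamino in place of hydroxy on a carbonyl carbon.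

Compound 3 `COc1cc2c(cc1OC)C(CC(=O)NC1CCCCC1)CC2` is the next candidate for this assay. It differs from compound 2 in one place: cyclohexyl in place of hexyl on an amide-type nitrogen. The amide-type nitrogen and its carbonyl carbon are retained. Among the compounds with values here, the measured step concerns the exchange of the acid for the amide and says nothing about exchanging hexyl for cyclohexyl; no measured step bears on this change. The expectation is therefore that compound 3 stays close to compound 2, with a number 4.2 percentage points lower from compound 2 to compound 3 (within the scatter) not beyond the scatter. Compound 3 is expected to give about 78% in this assay, within a range of 60% to 92%.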

Compound 3, a percentage reported as inhibition, in the whole organism at one dose (the size of the read-out at that dose, not a potency): 44.7%
Beside the measured number, compound 3's estimate is 33.3 percentage points above it, and the stated range ends above it.
By their numbers in this assay, from the lowest: compounds 1 and 3 (each within the scatter of the next); then compound 2.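

In this assay, the gain seen on going from the acid to the hexyl amide does not belong to the amide alone, since the group on the amide-type nitrogen also counts: cyclohexyl in place of hexyl came with a number 37.5 percentage points lower from compound 2 to compound 3 (beyond the scatter) even though both groups hold the same count of carbon atoms. Cyclohexylamino in place of hydroxy on a carbonyl carbon came with a number 0.7 percentage points higher from compound 1 to compound 3 (within the scatter) and thus, unlike hexylamino, shows no step beyond the scatter. Nothing at hand explains why the open chain and the ring part ways here.

Open, as far as these compounds go, is how the number in this assay follows chain length, as with butyl or octyl on the same nitrogen. Also open, from the compounds shown here alone, is whether cyclohexylmethyl or benzyl on that nitrogen stays with compound 2 or with compound 3.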